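Plasma Stability Across an Aryl Exchange

The source may hold more compounds than are shown below. What is called first, only, known or untested is meant among the compounds shown, and "the series" means these compounds.

Compound 2 `O=C(O)c1ccc(-c2cccc(COc3ccc4c(c3)CN(C3CCCC3)C4=O)c2)c(Cl)c1` is one of three compounds already measured in an ADME assay on a cell-free system (plasma, Rattus norvegicus) for metabolic stability, read by LC-MS, with a stated time of 1 h, at 37 degrees C, tested at 100 uM (on this read-out lower numbers stand for a less stable compound and higher numbers for a more stable compound), and in it compound 2 gives 100%. Compound 3 `Cn1sc2cc(OCc3cccc(-c4ccc(Cl)c(C(=O)O)c4)c3)ccc2c1=O` gives 100%, and compound 1 `O=C(O)c1cc(-c2cccc(COc3ccc4c(=O)n(C5CCC5)sc4c3)c2)ccc1Cl` gives 91%. Compound 2 therefore stands level with compound 3 at the digits printed, the two together holding the highest numbers of the three, while its gap to compound 1 lies within the scatter. Among the measured compounds shown here, the only step recorded between single-point neighbours, a number 9 percentage points higher from compound 1 to compound 3 (within the scatter), concerns the substituent on the aromatic nitrogen and leaves the aryl-carboxylic acid portion untouched.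

Compound 4 `COc1ccc(-c2cccc(COc3ccc4c(c3)CN(C3CCCC3)C4=O)c2)cc1C(=O)O` differs from compound 2 precisely in that portion: 3-carboxy-4-methoxyphenyl in place of 4-carboxy-2-chlorophenyl on an aromatic carbon. For the measured compounds named here, no measured step touches this part of the molecule, so the expectation rests only on the fact that all three measured compounds sit at or near the top of the scale in this assay. The step from compound 2 to compound 4 is expected to amount to a number 5 percentage points lower from compound 2 to compound 4 (within the scatter), nothing beyond the scatter. Compound 4 is thus estimated at 95% in this assay, with a range from 80% to 100%.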

Compound 4, percent of the compound remaining: 100%
For compound 4 the middle estimate is 5 percentage points below the measured one; the measured number falls inside the stated range.
By their numbers in this assay, from the lowest: compounds 1, 2, 3 and 4 (each within the scatter of the next).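

Among the compounds shown here, this step is the first reading at this position, on an aromatic carbon of the six-membered ring and meta to a large group: in this assay, putting 3-carboxy-4-methoxyphenyl in place of 4-carboxy-2-chlorophenyl gives no change at the digits printed from compound 2 to compound 4 (within the scatter). The earlier single-place step concerned only the substituent on the aromatic nitrogen, whereas this one shows that the reading holds when the aryl-carboxylic acid portion itself is exchanged, with chlorine leaving, a methoxy group entering and the carboxylic acid sitting differently on the ring. No measurement given here bears on why the reading stays the same across this exchange.

The step makes all of these alterations at once, so the compounds shown do not tell what the loss of chlorine, the gain of methoxy or the shift of the carboxylic acid would each do alone. They also leave open whether the reading would hold with a methyl ester or a primary amide in place of the carboxylic acid, since every compound shown carries the free acid.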